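From phenyl to 2,4-difluorophenyl on a shared core

The source may report more compounds than this note shows. Statements on the series, on what has been measured and on what is new or still open speak of the compounds shown alone.

Measured in a functional assay on NCI-H460 cells (Homo sapiens) for antiproliferative activity, with a stated time of 72 h; a higher number here means a weaker inhibitor, a lower number a stronger inhibitor:
- Compound 1 `Nc1ncnn2c([C@@H]3O[C@H](CO)[C@@H](O)[C@H]3O)cc(C#CC3CC3)c12`: 80 nM
- Compound 2 `Nc1ncnn2c([C@@H]3O[C@H](CO)[C@@H](O)[C@H]3O)cc(-c3ccccc3)c12`: > 100000 nM

Compound 2 reads > 100000 nM, which is a limit of the assay and not a number. Its standing is thus given only by the limit of > 100000 nM in this assay, at which 1 of the 2 values shown sits. Compound 3 `Nc1ncnn2c([C@@H]3O[C@H](CO)[C@@H](O)[C@H]3O)cc(-c3ccc(F)cc3F)c12` carries 2,4-difluorophenyl in place of phenyl on an aromatic carbon. For the measured compounds named here, one measured step bears on this change, and only indirectly: an at least 1200-fold higher number from compound 1 to compound 2 (3.09 log units; beyond the scatter), a large step that replaces 2-cyclopropylethynyl rather than altering the phenyl. Compound 3 still has a six-membered aromatic ring of carbon only in that place, so no step beyond the scatter is expected in this assay, and another limit reading is likely. The estimated change is a number no higher from compound 2 to compound 3 (the limit leaves the size open). For compound 3 the expected value is 100000 nM, within an estimated range from 20000 nM to 100000 nM.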

Compound 3, half-maximal inhibitory concentration: 93300 nM
The estimate for compound 3 lay 1.1-fold (0.03 log units) above the measured number; the measured number falls inside the stated range.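

In this assay, compound 3 gives the aromatic ring at this position a real number, where the earlier phenyl compound gave none. Compound 2 reads as a limit of the assay and not a number: the limit of > 100000 nM in this assay, at which 1 of the 3 values shown sits. Placing 2,4-difluorophenyl in place of phenyl gives an at least 1.0-fold lower number from compound 2 to compound 3 (0.03 log units; that floor lies within the scatter), so this change has no visible effect, while a 1200-fold higher number from compound 1 to compound 3 (3.07 log units; beyond the scatter) shows that the fluorinated ring, like phenyl, stays far from what 2-cyclopropylethynyl gives.

The compounds shown leave open whether it is the triple bond or the cyclopropyl ring of 2-cyclopropylethynyl that carries the activity, since only that group and two six-membered aromatic rings of carbon only appear here. A plain ethynyl group, a propynyl chain or a cyclopropyl ring attached directly at this position would separate those two parts.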